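This account rests on a few compounds, and the source may have more. Where it says the series, first, only, none or still open, it means among the compounds named here.

Compound 1 `CCc1ccc(-c2nc3c(c(C)nn3-c3ccccc3)c(-c3ccccc3Br)c2C#N)cc1` gives 1500 nM
Compound 2 `CCc1ccc(-c2nc3c(c(C)nn3-c3ccccc3)c(-c3ccccc3F)c2C#N)cc1` gives 1700 nM

In a physicochemical assay for solubility, read by spectrophotometry, in phosphate buffer, with a stated time of 18 h, at pH 7.4 (a higher number here means a more soluble compound, a lower number a less soluble compound), compound 2 sits at 1700 nM and stands within the scatter of compound 1. Compound 3 `CCc1ccc(-c2nc3c(c(C)nn3-c3ccccc3)c(-c3ccccc3S(C)(=O)=O)c2C#N)cc1` differs from compound 2 by methylsulfonyl in place of fluoro on an aromatic carbon and so has methylsulfonyl in place of fluoro on an aromatic carbon, ortho to a large group. Within the data shown here, the only measured step, a 1.1-fold higher number from compound 1 to compound 2 (0.05 log units; within the scatter) and fluoro in place of bromo, involves no methylsulfonyl and offers only weak guidance, so a modest rise is expected. The expected step is a 1.5-fold higher number from compound 2 to compound 3 (0.17 log units; within the scatter) and remains uncertain. Compound 3 is thus estimated at 2500 nM with 800 nM to 8000 nM as its range.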

Compound 3, solubility: 2200 nM
Compound 3: the middle estimate sits 1.1-fold (0.06 log units) above what was measured; the measured number falls inside the stated range.
By their numbers in this assay, from the lowest: compounds 1, 2 and 3 (each within the scatter of the next).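

In this assay, methylsulfonyl in place of fluoro on this aromatic carbon, ortho to a large group, gives a 1.3-fold higher number from compound 2 to compound 3 (0.11 log units; within the scatter), and methylsulfonyl in place of bromo gives a 1.5-fold higher number from compound 1 to compound 3 (0.17 log units; within the scatter). Among these compounds, the earlier pair exchanged only one halogen for another, whereas this change brings in 4 heavy atoms and 2 hydrogen-bond acceptors, and still no step at this position leaves the scatter. Nothing available explains this result. The compounds shown leave open whether an amine or a carboxylic acid on this carbon would move the number beyond the scatter.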